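The source may hold more compounds than are shown below. What is called first, only, known or untested is meant among the compounds shown, and "the series" means these compounds.

For the measured compounds named here, compound 2 `C/N=C(/S)[C@@]1(c2cccnc2)CCCC[C@@H]1CCNS(=O)(=O)c1cccs1` is one of two compounds measured in a functional assay (aorta) with Rattus norvegicus as the target; on this read-out lower numbers stand for stronger inhibition and higher numbers for weaker inhibition; compound 2 gives 1 nM, the lowest of the two numbers, and compound 1 `C/N=C(/S)[C@@]1(c2cccnc2)CCCC[C@@H]1CCNc1ccccc1` gives 3 nM. Going by the values given here, the one step between them, a 3.0-fold lower number from compound 1 to compound 2 (0.48 log units; beyond the scatter), shows that swapping the group on this amine nitrogen can move the number, though modestly. Compound 3 `C/N=C(/S)[C@@]1(c2cccnc2)CCCC[C@@H]1CCNC(=O)c1ccc(F)cc1` has not been measured in this assay. It differs from compound 2 in a single place: (4-fluorophenyl)carbonyl in place of (thiophen-2-yl)sulfonyl on an amine nitrogen. Among the compounds with values here, no measured step covers this exact exchange, so the only guide is that a change on the same nitrogen produced a modest shift in a 3.0-fold lower number from compound 1 to compound 2 (0.48 log units; beyond the scatter). On that basis a step of similar or smaller size is expected, direction uncertain, so that compound 3 is expected to give 2 nM (range 0.7 nM to 6 nM), which would mean a step of a 2.0-fold higher number from compound 2 to compound 3 (0.30 log units; within the scatter) from compound 2.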

Compound 3, concentration for 90% inhibition: 500 nM
Compound 3: the middle estimate sits 250-fold (2.40 log units) below what was measured; measured number above the stated range.
By their numbers in this assay, from the lowest: compound 2; then compound 1; then compound 3.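

In this assay, the amine nitrogen turns out to be far more sensitive than the earlier modest step suggested: there is a 500-fold higher number from compound 2 to compound 3 (2.70 log units; beyond the scatter), and also a 170-fold higher number from compound 1 to compound 3 (2.22 log units; beyond the scatter). Phenyl and (thiophen-2-yl)sulfonyl both keep the number low, so this position does not accept every aromatic group equally, and (4-fluorophenyl)carbonyl is the one exchange here that costs heavily. The data offer no measured explanation for this large loss.

This exchange alters the sulfonyl, the ring and the fluorine all at once, so the compounds shown leave open which of these accounts for the rise. Groups such as (thiophen-2-yl)carbonyl, (4-fluorophenyl)sulfonyl or plain phenylcarbonyl on the same nitrogen would help to separate these parts.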